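From benzyloxy to isopropyl: an estimate for compound 4

The compounds below may be only part of what the source reports. "The series", "measured", "known", "first", "only" and "open" are said of these compounds alone.

Compound 1 `CN1CCCN(CCn2ccc3ccc(Br)cc32)CC1`: 31 nM
Compound 2 `CN1CCCN(CCn2ccc3ccc(C(F)(F)F)cc32)CC1`: 23 nM
Compound 3 `CN1CCCN(CCn2ccc3ccc(OCc4ccccc4)cc32)CC1`: 182 nM

Three compounds sharing one core were tested in an assay on HEK293 cells for binding affinity to 5-hydroxytryptamine receptor 7 (Homo sapiens), read by radioligand binding; a higher number here means a weaker inhibitor, a lower number a stronger inhibitor. Compound 1 gives 31 nM and compound 2 gives 23 nM; the step of a 1.3-fold lower number from compound 1 to compound 2 (0.13 log units; within the scatter) lies within the scatter. Compound 3, carrying benzyloxy, gives 182 nM, the highest number of the three, with a 5.9-fold higher number from compound 1 to compound 3 (0.77 log units; beyond the scatter) and a 7.9-fold higher number from compound 2 to compound 3 (0.90 log units; beyond the scatter) both beyond the scatter.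

Compound 4 `CC(C)c1ccc2ccn(CCN3CCCN(C)CC3)c2c1` differs from compound 3 by isopropyl in place of benzyloxy on an aromatic carbon. Among the measured compounds shown here, the steps that bear on this change are the two that exchange a substituent without a ring for benzyloxy, a 5.9-fold higher number from compound 1 to compound 3 (0.77 log units; beyond the scatter) and a 7.9-fold higher number from compound 2 to compound 3 (0.90 log units; beyond the scatter); going the other way, from benzyloxy to a substituent without a ring, the number is therefore expected to fall in this assay by a comparable amount. Isopropyl is not bromo or trifluoromethyl, so the expected step of a 4.6-fold lower number from compound 3 to compound 4 (0.66 log units; beyond the scatter) is given a wide range. Compound 4 is estimated at 40 nM, between 15 nM and 120 nM.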

Compound 4, inhibition constant: 145 nM
Compound 4: middle estimate off by 3.6-fold (0.56 log units), on the low side; measured number above the stated range.
By their numbers in this assay, from the lowest: compounds 2 and 1 (each within the scatter of the next); then compounds 4 and 3 (each within the scatter of the next).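

In this assay, a substituent without a ring at this place does not by itself give the lower numbers: isopropyl stands with benzyloxy, with a 1.3-fold lower number from compound 3 to compound 4 (0.10 log units; within the scatter). Isopropyl instead parts from the other two ring-free groups, with a 4.7-fold higher number from compound 1 to compound 4 (0.67 log units; beyond the scatter) and a 6.3-fold higher number from compound 2 to compound 4 (0.80 log units; beyond the scatter), so among these four compounds the ring in compound 3 does not mark the divide, since compound 4 lies on the same side without one. Nothing measured here accounts for why isopropyl and benzyloxy group together, apart from bromo and trifluoromethyl.

The compounds shown leave open whether methyl or methoxy at this place would stand with bromo and trifluoromethyl or with isopropyl and benzyloxy. They also leave open where a nitrile or an amine would fall.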